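Swapping allyl for 2-(dimethylamino)ethyl: what to expect

The source may report more compounds than this note shows. Statements on the series, on what has been measured and on what is new or still open speak of the compounds shown alone.

compound 1 `CCC(=O)N(c1ccc(Cl)c(Cl)c1)C1CCCC1N` gives 0.8 mg/kg
compound 2 `CCNC1CCCC1N(C(=O)CC)c1ccc(Cl)c(Cl)c1` gives 2 mg/kg
compound 3 `C=CCN(C)C1CCCC1N(C(=O)CC)c1ccc(Cl)c(Cl)c1` gives 0.2 mg/kg

These three values come from a functional assay on the whole organism for antagonist activity, with Mus musculus as the target (a higher number here means that more compound is needed for the effect, a lower number that less compound is needed), and differ only in the group on one amine nitrogen. Compound 3 stands lowest at 0.2 mg/kg and so needs the least compound of the three.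

Compound 4 `CCC(=O)N(c1ccc(Cl)c(Cl)c1)C1CCCC1N(C)CCN(C)C` keeps the shared core and changes only the chain on that nitrogen. (Dimethylamino)methyl stands in place of vinyl on a saturated chain carbon bound to an amine nitrogen (dimethylamino)methyl in place of vinyl on a saturated chain carbon bound to an amine nitrogen and the same change reads as allyl to 2-(dimethylamino)ethyl.

Going by the values given here, no measured step makes this exact swap, so the nearest guides are the changes at the same nitrogen. Adding ethyl gave a 2.5-fold higher number from compound 1 to compound 2 (0.40 log units; beyond the scatter) while allyl(methyl)amino in place of amino gave a 4.0-fold lower number from compound 1 to compound 3 (0.60 log units; beyond the scatter) and allyl(methyl)amino in place of ethylamino gave a 10-fold lower number from compound 2 to compound 3 (1.00 log units; beyond the scatter) as the widest move. These steps run both ways, so the direction is uncertain. However, compound 3 at 0.2 mg/kg already sits at the low end, which leaves a rise as the likelier outcome. The expected change is a 4.0-fold higher number from compound 3 to compound 4 (0.60 log units; beyond the scatter) as a modest step of similar size to those measured. For compound 4 the estimate is 0.8 mg/kg with an expected range from 0.15 mg/kg to 4 mg/kg as its limits.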

Compound 4, dose for half-maximal effect: 5 mg/kg
Beside the measured number, compound 4's estimate is 6.3-fold (0.80 log units) below it; measured number outside the range, above it.
By their numbers in this assay, from the lowest: compound 3; then compound 1; then compound 2; then compound 4.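

In this assay, the change from allyl to 2-(dimethylamino)ethyl is the largest step yet seen at this nitrogen, a 25-fold higher number from compound 3 to compound 4 (1.40 log units; beyond the scatter), so the choice of chain here can move the dose considerably. Going by these compounds alone, the new chain also ends above the smaller groups, with a 2.5-fold higher number from compound 2 to compound 4 (0.40 log units; beyond the scatter) and a 6.3-fold higher number from compound 1 to compound 4 (0.80 log units; beyond the scatter), which makes compound 4 the one needing the most compound of the four. Compound 3 and compound 4 both keep the methyl on this nitrogen, so that methyl alone does not bring the low dose, and nothing measured here accounts for the rise.

The compounds shown leave open whether the rise goes with the added nitrogen of the dimethylamino group or simply with the longer chain, as vinyl and (dimethylamino)methyl differ in both respects. A plain butyl chain in this place would help separate the two, and a 2-methoxyethyl chain would show whether another atom in place of that nitrogen gives a similar number.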